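Swapping the Aroyl Group: From Compound 2 to Compound 4

The compounds below may be only part of what the source reports. "The series", "measured", "known", "first", "only" and "open" are said of these compounds alone.

Measured compounds in a functional assay on A549 cells (Homo sapiens) for cytotoxicity, read by MTT assay, with a stated time of 48 h; on this read-out lower numbers stand for stronger inhibition and higher numbers for weaker inhibition:
compound 1 `COc1cc(-c2nnc3n2NC(c2cccs2)C(C(=O)c2ccc(C)cc2)S3)cc(OC)c1OC`: 12700 nM
compound 2 `COc1ccc(C(=O)C2Sc3nnc(-c4cc(OC)c(OC)c(OC)c4)n3NC2c2ccco2)cc1`: > 100000 nM
compound 3 `COc1ccc(C(=O)C2Sc3nnc(-c4cc(OC)c(OC)c(OC)c4)n3NC2c2cccs2)cc1`: > 100000 nM

Of the compounds shown here, three sharing one core have been tested in this assay. Compound 1 gives 12700 nM. Compound 2 reaches only a limit of the assay, > 100000 nM, and no number. Compound 3 likewise sits at a limit, > 100000 nM. the limit of > 100000 nM in this assay, at which 2 of the 3 values shown sit, therefore covers two of the three values. Among the measured compounds shown here, the only readable step is an at least 7.8-fold higher number from compound 1 to compound 3 (0.89 log units; beyond the scatter); the step that the two limits leave unreadable from compound 2 to compound 3 cannot be sized. Compound 4 `COc1cc(-c2nnc3n2NC(c2ccco2)C(C(=O)c2ccccc2F)S3)cc(OC)c1OC` has not yet been measured. Compared with compound 2, its change is 2-fluorophenyl in place of 4-methoxyphenyl on a carbonyl carbon. The step from compound 1 to compound 3 bears on it, since there a methoxy in place of a methyl weakened the compound; going the other way, from 4-methoxyphenyl to 2-fluorophenyl, might lower the number, but as compound 2 starts from a limit, the size cannot be judged. Compound 4 is therefore expected to give about 40000 nM, within 8000 nM to 150000 nM, an expected step of an at least 2.5-fold lower number from compound 2 to compound 4 (0.39 log units; beyond the scatter).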

Compound 4, half-maximal inhibitory concentration: 78700 nM
Compound 4: the middle estimate sits 2.0-fold (0.29 log units) below what was measured; the range from low to high includes it.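

In this assay, compound 4 is the first compound shown with a furan-2-yl group to give a number rather than a limit, so this carbonyl position can carry a group that keeps the read-out within the range of the assay. The change from (4-methoxyphenyl)carbonyl to (2-fluorophenyl)carbonyl gives an at least 1.2-fold lower number from compound 2 to compound 4 (0.10 log units; that floor lies within the scatter), so a real gain is not shown, although a larger one is not excluded. That step can be stated only as a floor because one end of it rests on a limit: the limit of > 100000 nM in this assay, at which 2 of the 4 values shown sit.

The compounds shown leave open whether the fluorine or the loss of the methoxy matters, as no unsubstituted phenyl appears at this position. Also open, as far as these compounds go, is how a phenyl carrying an amine or a carboxylic acid would read here, or how 2-fluorophenyl would read with thiophen-2-yl on the saturated ring carbon.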